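Lengthening the ester side chain of compound 1

The source may report more compounds than this note shows. Statements on the series, on what has been measured and on what is new or still open speak of the compounds shown alone.

In a functional assay on T-24 cells (Homo sapiens) for antiproliferative activity, read by sulforhodamine B assay, with a stated time of 72 h (a lower number here means a stronger inhibitor, a higher number a weaker inhibitor), compound 1 (`C=CCOC(=O)C1=C2C(=NC1=O)c1cccc3c(SCCC)ccc2c13`) gives 13100 nM as the second highest of three numbers. Going by the values given here, compound 2 (`CCCSc1ccc2c3c(cccc13)C1=NC(=O)C(C(=O)OCC)=C12`) reads lower at 1700 nM and compound 3 (`C=CCSc1ccc2c3c(cccc13)C1=NC(=O)C(C(=O)OCC(=O)SCCC)=C12`) reads higher at 71800 nM in this assay so far.

Compound 4 (`CCCSC(=O)COC(=O)C1=C2C(=NC1=O)c1cccc3c(SCCC)ccc2c13`) is still unmeasured. It carries (propylsulfanyl)carbonyl in place of vinyl on a saturated chain carbon bound to an oxygen next to a carbonyl group. Among the compounds with values here, only one measured step touches that place, a 7.7-fold lower number from compound 1 to compound 2 (0.89 log units; beyond the scatter) with methyl as the entering group, so it shows that the number can move there but not how this larger group will act. Within the data shown here, compound 3 at 71800 nM is the only measured compound carrying (propylsulfanyl)carbonyl at that place, and this points upward, although no measured step isolates the group. A moderate rise is therefore expected, amounting to an estimated 2.7-fold higher number from compound 1 to compound 4 (0.43 log units; beyond the scatter) in this assay once measured. Compound 4 is estimated at 35000 nM with an expected range from 12000 nM to 90000 nM in this assay.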

Compound 4, half-maximal inhibitory concentration: 79100 nM
Compound 4: the middle estimate sits 2.3-fold (0.35 log units) below what was measured; measured number inside the range.
By their numbers in this assay, from the lowest: compound 2; then compound 1; then compounds 3 and 4 (each within the scatter of the next).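

In this assay, the place on a saturated chain carbon bound to an oxygen next to a carbonyl group now has a measured step for a large entering group: (propylsulfanyl)carbonyl in place of vinyl moves the number up (a 6.0-fold higher number from compound 1 to compound 4 (0.78 log units; beyond the scatter)). The same group in place of methyl gives the largest step in the series (a 47-fold higher number from compound 2 to compound 4 (1.67 log units; beyond the scatter)), so the earlier drop seen with methyl now has a counterpart in the opposite direction. With this side chain in place, ethyl in place of vinyl on a saturated chain carbon bound to a sulfur separates nothing (a 1.1-fold higher number from compound 3 to compound 4 (0.04 log units; within the scatter)). No measurement shown here explains these steps.

As far as these compounds go, what remains open is whether the rise follows the sulfur, the carbonyl or simply the length of the side chain, which a longer plain alkyl chain or a terminal carboxylic acid at this place would help to separate. From the compounds shown here alone, it is also open whether ethyl in place of vinyl on the sulfur-bound chain would stay as silent alongside the smaller allyl or ethyl esters.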